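The compounds below may be only part of what the source reports. "The series", "measured", "known", "first", "only" and "open" are said of these compounds alone.

Of the compounds shown here, three built on one shared core have been tested in an assay on isolated protein for inhibition of Indoleamine 2,3-dioxygenase 1 (Homo sapiens), read by fluorescence, with a stated time of 60 min; on this read-out lower numbers stand for stronger inhibition and higher numbers for weaker inhibition. Compound 1 `NS(=O)(=O)NNc1nonc1/C(=N/O)Nc1ccc(F)c(Br)c1` gives 218 nM in this assay. Compound 2 `C#CCNS(=O)(=O)CCNc1nonc1/C(=N/O)Nc1ccc(F)c(Br)c1` gives 218 nM in this assay. Compound 3 `O=S(=O)(CCNc1nonc1/C(=N/O)Nc1ccc(F)c(Br)c1)NO` gives 126 nM in this assay. The three numbers lie close together: no change at the digits printed from compound 1 to compound 2 (within the scatter), a 1.7-fold lower number from compound 1 to compound 3 (0.24 log units; within the scatter) and a 1.7-fold lower number from compound 2 to compound 3 (0.24 log units; within the scatter). Compound 3 thus carries the lowest of the three numbers, yet its gap to each of the other two stays within the scatter, so no ranking among the three can be drawn from them.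

Compound 4 `NS(=O)(=O)CCCNc1nonc1/C(=N/O)Nc1ccc(F)c(Br)c1` has not been measured yet. It differs from compound 3 in a single place: sulfamoylmethyl in place of hydroxysulfamoyl on a saturated chain carbon, two bonds along the chain from a nitrogen on an aromatic ring. The measured steps that bear on this are the two that already reworked the sulfonamide-bearing end of the same side chain, from compound 1 to compound 3 and from compound 2 to compound 3, and both moved this assay only within the scatter. On that basis the change to compound 4 is expected to leave the number where compound 3 sits, with no step beyond the scatter, expressed as a 1.4-fold higher number from compound 3 to compound 4 (0.15 log units; within the scatter). Compound 4 is therefore estimated at 180 nM in this assay, with a range from 80 nM to 400 nM.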

Compound 4, half-maximal inhibitory concentration: 126 nM
For compound 4 the middle estimate is 1.4-fold (0.15 log units) above the measured one; measured number inside the range.
By their numbers in this assay, from the lowest: compounds 3, 4, 1 and 2 (each within the scatter of the next).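

In this assay, putting sulfamoylmethyl in place of hydroxysulfamoyl on a saturated chain carbon, two bonds along the chain from a nitrogen on an aromatic ring, gives no change at the digits printed from compound 3 to compound 4 (within the scatter), so the hydroxy on the sulfonamide nitrogen is shown to be dispensable here, even though the side chain changes from 2-(hydroxysulfamoyl)ethyl to 3-sulfamoylpropyl and the end group goes from 2 hydrogen-bond donors and 3 acceptors to 1 donor and 2 acceptors. The other two comparisons, a 1.7-fold lower number from compound 2 to compound 4 (0.24 log units; within the scatter) and a 1.7-fold lower number from compound 1 to compound 4 (0.24 log units; within the scatter), also stay within the scatter, so a plain sulfamoyl end on the propyl chain sits with the propargyl-substituted and sulfamoylamino side chains in this assay. No other measurement is at hand that could explain why these side chains read so alike.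

Every side chain shown carries a sulfamoyl group, so what a carboxylic acid, a primary amine or a longer chain such as 4-sulfamoylbutyl would do at this place remains open. All four compounds also keep the rest of the core unchanged, which leaves open what chlorine in place of the bromine would do.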